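Oxolane for pyrrolidine on the ether side chain

This account rests on a few compounds, and the source may have more. Where it says the series, first, only, none or still open, it means among the compounds named here.

Compound 3 `Cc1cc(-c2c(O)nc3cc(Cl)c(C(=O)Nc4ccncn4)cc3c2OCC[C@@H]2CCCN2)cc(C)c1C` gives 2.2 nM in a functional assay on CHO cells for inhibition of Gonadotropin-releasing hormone receptor (Homo sapiens) (on this read-out lower numbers stand for stronger inhibition and higher numbers for weaker inhibition), level with compound 1 `Cc1cc(-c2c(O)nc3cc(Cl)c(C(=O)Nc4ccncn4)cc3c2OCC[C@@H]2CCCCN2)cc(C)c1C`, which gives 2.2 nM, and together these are the lowest of the three numbers. Compound 2 `Cc1cc(-c2c(O)nc3cc(Cl)c(C(=O)Nc4cnsn4)cc3c2OCC[C@H]2CCO2)cc(C)c1C`, which also carries an oxolan-2-yl ring on the side chain but differs at the amide as well, gives 49 nM. Going by the values given here, the only single-point step, no change at the digits printed from compound 1 to compound 3 (within the scatter), shows that the ring size of the amine at that position makes no difference within the scatter.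

Compound 4 `Cc1cc(-c2c(O)nc3cc(Cl)c(C(=O)Nc4ccncn4)cc3c2OCCC2CCCO2)cc(C)c1C` is the next compound, with the change (oxolan-2-yl in place of pyrrolidin-2-yl on a saturated chain carbon, two bonds along the chain from an oxygen on an aromatic ring). The hydrogen-bond donor of the ring is lost. Among the compounds with values here, no measured step isolates this exchange; compound 2 is the only other compound with an oxolane, and its higher number cannot be assigned to one change. A step of moderate size in the direction of weaker inhibition is expected, a 4.5-fold higher number from compound 3 to compound 4 (0.66 log units; beyond the scatter). Compound 4 is estimated at 10 nM, with a range from 3 nM to 40 nM.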

Compound 4, half-maximal inhibitory concentration: 3.3 nM
Compound 4: middle estimate off by 3.0-fold (0.48 log units), on the high side; the measured number falls inside the stated range.
By their numbers in this assay, from the lowest: compounds 1, 3 and 4 (each within the scatter of the next); then compound 2.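

Oxolan-2-yl in place of pyrrolidin-2-yl gives a 1.5-fold higher number from compound 3 to compound 4 (0.18 log units; within the scatter) and oxolan-2-yl in place of piperidin-2-yl gives a 1.5-fold higher number from compound 1 to compound 4 (0.18 log units; within the scatter) in this assay. Going by these compounds alone, the earlier compounds showed only that two amine rings were level at this position, whereas these steps place a ring with 0 hydrogen-bond donors within the scatter of both. Among compounds 1, 3 and 4, a hydrogen-bond donor in this ring is therefore not required for a number in this range, and no measurement at hand explains the result.

On these data alone, whether the single stereoisomers of the oxolan-2-yl compound differ remains open, as compound 4 has no defined stereocentre in this group. Also open, as far as these compounds go, is how this position responds to an open-chain dimethylamino group, a carboxylic acid or a longer chain between the ether oxygen and the ring.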